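The compounds below may be only part of what the source reports. "The series", "measured", "known", "first", "only" and "open" are said of these compounds alone.

In a functional assay on Jurkat cells (Homo sapiens) for cytotoxicity, with a stated time of 72 h (on this read-out lower numbers stand for an effect already at smaller amounts and higher numbers for an effect only at larger amounts of compound), compound 1 `CCOC(=O)/C(C)=C/c1cc(/C=C/[C@](C)(/C=C/c2ccc(OC)cc2)CCC=C(C)C)ccc1O` gives > 49000 nM, which is a limit of the assay and not a number. In this assay compound 2 `COc1ccc(/C=C/[C@@](C)(/C=C/c2ccc(O)c(/C=C/C(=O)OCc3ccccc3)c2)CCC=C(C)C)cc1` gives > 49000 nM, which is likewise only a limit. Among the compounds with values here, compound 2 therefore has no numerical position, and the whole series so far rests on (the limit of > 49000 nM in this assay, at which 2 of the 2 values shown sit).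

Compound 3 `COc1ccc(/C=C/[C@@](C)(/C=C/c2ccc(O)c(/C=C/C(C)=O)c2)CCC=C(C)C)cc1` differs from compound 2 by methyl in place of benzyloxy on a carbonyl carbon. Put another way, 2-(benzyloxycarbonyl)ethenyl becomes 2-acetylethenyl.

Within the data shown here, only one measured step bears on this part of the structure: a step that the two limits leave unreadable from compound 1 to compound 2. It places 2-(benzyloxycarbonyl)ethenyl in place of 2-(ethoxycarbonyl)prop-1-en-1-yl on an aromatic carbon, and it offers no size to carry forward. Among the measured compounds shown here, no measured step shows the effect of the present change. The expectation in this assay is thus for no large shift, with any readable value likely to lie only modestly towards smaller amounts.

The expected change is an at least 1.6-fold lower number from compound 2 to compound 3 (0.21 log units; that floor lies within the scatter), and this remains an estimate. For compound 3 the estimated value is 30000 nM, with an expected range of 8000 nM to 49000 nM.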

Compound 3, half-maximal effective concentration: > 49000 nM
Compound 3: a limit, no number; the forecaster's own chance of this, stated with the estimate: 60%; middle value at least 1.6-fold (0.21 log units) from the limit.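

In this assay compound 3 gives > 49000 nM, which is a limit of the assay and not a number. Within the data shown here, no step among compound 1, compound 2 and compound 3 can be read, and the series rests on one limit: the limit of > 49000 nM in this assay, at which 3 of the 3 values shown sit. The compounds shown leave open whether any change to the shared core gives a readable value in this assay.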